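Difluorophenyl for chlorophenyl at the biaryl position

The source may report more compounds than this note shows. Statements on the series, on what has been measured and on what is new or still open speak of the compounds shown alone.

Measured so far:
compound 1 `Cn1cncc1C(OCc1ccc(C#N)cc1-c1cccc(Cl)c1)c1ccc(C#N)nc1`: 2.1 nM
compound 2 `Cn1cncc1C(OCc1ccc(C#N)nc1-c1cccc(Cl)c1)c1ccc(C#N)cc1`: 1.8 nM

In a functional assay on NIH3T3 cells (Mus musculus) (a lower number here means that less compound is needed, a higher number that more compound is needed for the effect), compound 1 gives 2.1 nM, the higher of the two numbers. Compound 2 gives 1.8 nM, which lies within the scatter of compound 1, so the two are not separated. Compound 3 `Cn1cncc1C(OCc1ccc(C#N)cc1-c1cc(F)cc(F)c1)c1ccc(C#N)nc1` is not yet measured. Relative to compound 1 the change is 3,5-difluorophenyl in place of 3-chlorophenyl on an aromatic carbon. Among the measured compounds shown here, no measured pair shows this change, so its size is open. The expected step is a 1.7-fold higher number from compound 1 to compound 3 (0.22 log units; within the scatter), a modest rise in the number at most, possibly none beyond the scatter. Compound 3 is expected to give 3.5 nM in this assay, with a range of 1.2 nM to 10 nM.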

Compound 3, half-maximal effective concentration: 25 nM
The estimate for compound 3 lay 7.1-fold (0.85 log units) below the measured number; measured number above the stated range.
By their numbers in this assay, from the lowest: compounds 2 and 1 (each within the scatter of the next); then compound 3.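

In this assay, the aromatic carbon carrying the 3-chlorophenyl group proves sensitive to the choice of aryl group: 3,5-difluorophenyl in its place gives a 12-fold higher number from compound 1 to compound 3 (1.08 log units; beyond the scatter). Among the compounds shown here, the earlier compounds showed no step at this position, so this is the first sign that the series does not accept every halogen-bearing phenyl here. Nothing available accounts for the size of this step.

As far as these compounds go, how 3-fluorophenyl, 3,5-dichlorophenyl or unsubstituted phenyl would stand here remains open, so the step cannot yet be divided between losing chlorine and adding two fluorines. From the compounds shown here alone, whether the same change carries over to compound 2 is also open.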